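Swapping an Aryl Ether for a Benzylamine on a Quinoxaline-Like Core

The source may report more compounds than this note shows. Statements on the series, on what has been measured and on what is new or still open speak of the compounds shown alone.

Measured compounds:
- compound 1, `Nc1cc(N)c2nc(-c3ccccc3)c(Oc3ccc(Cl)c(Cl)c3)nc2c1`: 16200 nM
- compound 2, `CCOC(=O)[C@H](CCC(=O)O)NC(=O)c1ccc(CNc2nc3cc(N)cc(N)c3nc2-c2ccccc2)cc1`: < 100000 nM
- compound 3, `CCOC(=O)[C@H](CCC(=O)O)NC(=O)c1ccc(Sc2nc3cc(N)cc(N)c3nc2-c2ccccc2)cc1`: 17800 nM

In a functional assay on UACC-62 cells (Homo sapiens) for inhibition, read by sulforhodamine B assay, with a stated time of 48 h (a lower number here means a stronger inhibitor of growth, a higher number a weaker inhibitor of growth), compound 1 gives 16200 nM. Compound 3 in this assay gives 17800 nM, a number within the scatter of compound 1, so the two cannot be ordered. Compound 2 in this assay gives only a limit, < 100000 nM, and not a number (the limit of < 100000 nM in this assay, at which 1 of the 3 values shown sits). Among the two numbers shown, compound 1 has the lower one.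

Compound 4, `Nc1cc(N)c2nc(-c3ccccc3)c(NCc3ccc(F)cc3)nc2c1`, has not yet been measured. It differs from compound 1 in one place: (4-fluorobenzyl)amino in place of 3,4-dichlorophenoxy on an aromatic carbon. For the measured compounds named here, no measured pair shows this exact change. Going by the values given here, the shared core is kept, and the two numbers measured so far sit close together, so the step from compound 1 to compound 4 is expected to be small, if any, with a lean towards a weaker inhibitor. Compound 4 is estimated at 22000 nM in this assay, within the range 6000 nM to 80000 nM, an expected step of a 1.4-fold higher number from compound 1 to compound 4 (0.13 log units; within the scatter).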

Compound 4, concentration for 50% growth inhibition: 15500 nM
Beside the measured number, compound 4's estimate is 1.4-fold (0.15 log units) above it; the measured number falls inside the stated range.
By their numbers in this assay, from the lowest: compounds 4, 1 and 3 (each within the scatter of the next).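

In this assay the swap of 3,4-dichlorophenoxy for (4-fluorobenzyl)amino gives a 1.0-fold lower number from compound 1 to compound 4 (0.02 log units; within the scatter) and separates the two compounds by no readable amount. For the compounds shown here, this is the first direct reading of a single change at this aromatic carbon, next to the ring nitrogen and ortho to a phenyl group: the entering group has 1 hydrogen-bond donor where the leaving group has 0, and 1 fluorine where it had 2 chlorine, yet the number holds within the scatter. Nothing measured here explains why the two groups read alike.

The linking atom and the ring substituents change together in this one step, and their separate contributions cannot be told apart. As far as these compounds go, how a morpholine or a longer chain such as 2-(4-fluorophenyl)ethylamino would read at this carbon remains open.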